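The compounds below may be only part of what the source reports. "The series", "measured", "known", "first", "only" and "open" are said of these compounds alone.

Four compounds are compared here, all built on the same kind of scaffold but in two cores. Compound 1 `COc1cccc(/C=C2\CCC/C(=C\c3ccc(Cl)cc3Cl)C2=O)c1OC` and compound 2 `COc1cccc(/C=C2\CCC/C(=C\c3ccc(Cl)c(Cl)c3)C2=O)c1OC` share one core; compound 3 `COc1ccc(/C=C2\CCC/C(=C\c3ccc(Cl)cc3Cl)C2=O)cc1OC` and compound 4 `COc1ccc(/C=C2\CCC/C(=C\c3ccc(Cl)c(Cl)c3)C2=O)cc1OC` share another, and the difference between the two cores is not broken down here. In an ADME assay on NHDF cells (Homo sapiens) for cytotoxicity, read by MTT assay, with a stated time of 72 h (a higher number here means a weaker inhibitor, a lower number a stronger inhibitor), compound 1 gives 49200 nM. In this assay compound 2 gives 25500 nM. The change between them is 3,4-dichlorophenyl in place of 2,4-dichlorophenyl on a double-bonded chain carbon bound to a double-bonded ring carbon, and it made a 1.9-fold lower number from compound 1 to compound 2 (0.29 log units; within the scatter). Compound 3 in this assay reaches only a limit, > 50000 nM, one of the values sitting at the limit of > 50000 nM in this assay, at which 1 of the 3 values shown sits. Compound 4 differs from compound 3 by 3,4-dichlorophenyl in place of 2,4-dichlorophenyl on a double-bonded chain carbon bound to a double-bonded ring carbon, the same change as before. With the earlier step inside the usual scatter, the step from compound 3 to compound 4 is expected to be small as well, at an at least 1.2-fold lower number from compound 3 to compound 4 (0.09 log units; that floor lies within the scatter). Compound 4 is therefore expected to give roughly 40000 nM, somewhere between 20000 nM and 100000 nM, and because compound 3 sits at the limit of > 50000 nM in this assay, at which 1 of the 3 values shown sits, the answer for compound 4 may itself turn out to be only a limit rather than a number.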

Compound 4, half-maximal inhibitory concentration: 10100 nM
Compound 4: middle estimate off by 4.0-fold (0.60 log units), on the high side; measured number outside the range, below it.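

In this assay, putting 3,4-dichlorophenyl in place of 2,4-dichlorophenyl on the core of compound 3 gave an at least 4.9-fold lower number from compound 3 to compound 4 (0.69 log units; beyond the scatter), a step that clearly exceeds the usual scatter. On the core of compound 1 the same change stayed within the scatter, so this pair of results neither shows that the change carries over unchanged nor proves that the two cores respond differently: the same change on two cores in this assay, a 1.9-fold lower number (0.29 log units; within the scatter) from compound 1 to compound 2 and an at least 4.9-fold lower number (0.69 log units; beyond the scatter) from compound 3 to compound 4; the limit leaves it open whether they differ Compound 3 gives > 50000 nM, which is a limit and not a number, so its step has a known minimum but no known full size: the limit of > 50000 nM in this assay, at which 1 of the 4 values shown sits.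

With only two cores and two dichlorophenyl patterns shown, it remains open whether the larger step on the core of compound 3 is real or would shrink or grow with an exact value for compound 3. From the compounds shown here alone, it is also open how this place in the molecule would respond to other groups, such as a 4-chlorophenyl, a 4-methoxyphenyl or an amine-bearing phenyl ring.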